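The source may hold more compounds than are shown below. What is called first, only, known or untested is meant among the compounds shown, and "the series" means these compounds.

Compound 3 `CCN1CCc2c(c(C(C)(C)C)nn2C(=O)Nc2c(C)cccc2C)C1` gives 73.7% in a functional assay on the whole organism (strain Swiss albino) for inhibition, with Mus musculus as the target, in the writhing test, with a stated time of 30 min, at a dose of 100 mg/kg; a lower number here means less inhibition, a higher number more inhibition at the dose given (going by the name of the read-out). Among the three measured compounds its number is the highest shown, though compound 2 `CCN1CCc2c(c(C(C)(C)C)nn2C(=O)Nc2ccc(Br)cc2)C1` comes close with 72.8%, within the scatter, while compound 1 `CCN1CCc2c(c(C)nn2C(=O)Nc2cc(C)ccc2C)C1` lies furthest away with 62.2%, beyond the scatter.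

Compound 4 `CCN1CCc2c(c(C(C)(C)C)nn2C(=O)Nc2cc(C)ccc2C)C1` has not yet been measured in this assay. It differs from compound 3 in one place: 2,5-dimethylphenyl in place of 2,6-dimethylphenyl on an amide-type nitrogen. Among the compounds with values here, the only measured step that changes the group on the amide-type nitrogen is the one from compound 2 to compound 3, where 2,6-dimethylphenyl replaced 4-bromophenyl and the inhibition moved by a number 0.9 percentage points higher from compound 2 to compound 3 (within the scatter), within the scatter. Within the data shown here, compound 1 carries the same 2,5-dimethylphenyl as compound 4, but it also carries methyl where compounds 3 and 4 carry tert-butyl, so its gap to compound 3 cannot be assigned to the aryl group alone, and no step between compound 1 and compound 4 is available. Among the measured compounds shown here, the one aryl swap on record was flat, so for compound 4 a step of about a number 3.7 percentage points lower from compound 3 to compound 4 (within the scatter) is expected, within the scatter. Compound 4 is therefore estimated at 70%, with a range from 58% to 80%.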

Compound 4, a percentage reported as inhibition, in the whole organism at one dose (the size of the read-out at that dose, not a potency): 63.1%
Compound 4: the middle estimate sits 6.9 percentage points above what was measured, and the stated range covers the measured number.
By their numbers in this assay, from the lowest: compounds 1, 4, 2 and 3 (each within the scatter of the next, the first and the last beyond it).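

In this assay, within the data shown here, the aryl group on the amide-type nitrogen now shows an effect for the first time: 2,5-dimethylphenyl in place of 2,6-dimethylphenyl gives a number 10.6 percentage points lower from compound 3 to compound 4 (beyond the scatter) as a modest step, even though the two groups have the same atoms and the same counts, whereas the earlier swap gave a number 0.9 percentage points higher from compound 2 to compound 3 (within the scatter) and suggested that this place made little difference. The picture is narrower than a general rule, however, as 2,5-dimethylphenyl in place of 4-bromophenyl gives a number 9.7 percentage points lower from compound 2 to compound 4 (within the scatter) and so does not clearly separate those two groups, which leaves 2,6-dimethylphenyl set apart only from 2,5-dimethylphenyl. With 2,5-dimethylphenyl held fixed, tert-butyl in place of methyl on an aromatic carbon gives a number 0.9 percentage points higher from compound 1 to compound 4 (within the scatter) and so does not register in this pair, and nothing available explains either result.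

The compounds shown leave open whether 2,6-dimethylphenyl keeps its number when methyl stands in place of tert-butyl. From the compounds shown here alone, how a plain phenyl or a 2,6-dichlorophenyl group would read on the same nitrogen also remains open.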